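Replacing bromo with isopropoxy in compound 2

The source may hold more compounds than are shown below. What is called first, only, known or untested is meant among the compounds shown, and "the series" means these compounds.

In a functional assay on MCF7 cells (Homo sapiens) for antiproliferative activity, read by sulforhodamine B assay, with a stated time of 72 h (a higher number here means a weaker inhibitor, a lower number a stronger inhibitor), compound 2 (`O=C(/C=C/c1csc2ccccc12)c1cc(Br)ccc1O`) gives 1040 nM as the lowest number shown, and compound 3 (`O=C(/C=C/c1csc2ccccc12)c1cc(Br)cc(Br)c1O`) gives 5800 nM by comparison. Compound 1 (`COc1cc2occ(-c3csc4ccccc34)c(=O)c2c(OC)c1O`) gives > 10000 nM and this is a limit, not a number. Compound 4 (`CC(C)Oc1ccc(O)c(C(=O)/C=C/c2csc3ccccc23)c1`) has not yet been measured. Relative to compound 2 it carries isopropoxy in place of bromo on an aromatic carbon. For the measured compounds named here, only one measured step bears on this, and only loosely: it puts bromo in place of hydrogen on an aromatic carbon. Given a 5.6-fold higher number from compound 2 to compound 3 (0.75 log units; beyond the scatter) as that step, a modest move to a higher number is expected in this assay rather than none. The expected step is a 1.9-fold higher number from compound 2 to compound 4 (0.28 log units; within the scatter) overall. For compound 4 the estimated value is 2000 nM with a range from 600 nM to 7000 nM expected.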

Compound 4, half-maximal inhibitory concentration: 6600 nM
Compound 4: middle estimate off by 3.3-fold (0.52 log units), on the low side; the range from low to high includes it.
By their numbers in this assay, from the lowest: compound 2; then compounds 3 and 4 (each within the scatter of the next). At a limit, above all of these: compound 1.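

Until now, the only change shown was a second bromo added to the ring of compound 2; here the original bromo itself, para to a hydroxy group, is exchanged. In this assay isopropoxy in its place gives a 6.3-fold higher number from compound 2 to compound 4 (0.80 log units; beyond the scatter) and so shows that this carbon does not accept every group equally. Nothing available explains this step. On these data alone, with only bromo and isopropoxy compared at this carbon, it stays open how hydrogen, an amine or a carboxylic acid would fare there.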